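Pyridinyl placement on the shared core: working notes

A few compounds are considered here, and "the series" means these few. Any claim that something is new, unique, unknown or untested is made for them only; others in the source may bear on it.

Measured compounds:
Compound 1 `CN(C)c1cccc(Nc2nccc(-c3cccnc3)n2)c1` gives 1800 nM in a functional assay for inhibition, with Homo sapiens as the target; on this read-out higher numbers stand for weaker inhibition and lower numbers for stronger inhibition.
Compound 2 `CN(C)c1cccc(Nc2nccc(-c3ccccn3)n2)c1` gives 400 nM in this assay.
Compound 3 `CC(=O)Nc1cccc(Nc2nccc(-c3cccnc3)n2)c1` gives 3600 nM in this assay.

Compound 1 and compound 2 differ only by pyridin-2-yl in place of pyridin-3-yl on an aromatic carbon; this gives a 4.5-fold lower number from compound 1 to compound 2 (0.65 log units; beyond the scatter). Compound 1 and compound 3 differ by acetamido in place of dimethylamino on an aromatic carbon, and here the step is a 2.0-fold higher number from compound 1 to compound 3 (0.30 log units; within the scatter), so the two cores cannot be told apart on this read-out. Compound 3 stands at the highest of the three numbers, but only its gap to compound 2 is beyond the scatter; against compound 1 nothing can be ordered.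

Compound 4 `CC(=O)Nc1cccc(Nc2nccc(-c3ccccn3)n2)c1` has not been measured. It differs from compound 3 by pyridin-2-yl in place of pyridin-3-yl on an aromatic carbon. This is the same change as from compound 1 to compound 2, on the same place of the shared core, and it appears in two pairs of compounds in this set. Among the measured compounds shown here, with only one measured instance, the size of the step carries uncertainty, and whether the acetamido-bearing core responds as the dimethylamino-bearing core does is not known from these data.

For the measured compounds named here, the expectation rests on compound 1 and compound 2, because a 4.5-fold lower number from compound 1 to compound 2 (0.65 log units; beyond the scatter) is the only measured step of this kind. Compound 4 is expected to show a step of a 4.5-fold lower number from compound 3 to compound 4 (0.65 log units; beyond the scatter) in this assay. Compound 4 is therefore estimated at 800 nM, with a range from 350 nM to 1800 nM.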

Compound 4, half-maximal inhibitory concentration: 300 nM
Estimate against measurement, compound 4: 2.7-fold (0.43 log units) above; measured number below the stated range.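

In this assay the change to pyridin-2-yl from pyridin-3-yl keeps its direction on the acetamido-bearing core, with a 12-fold lower number from compound 3 to compound 4 (1.08 log units; beyond the scatter), but its size does not carry over unchanged from the dimethylamino-bearing core: the same change on two cores in this assay, a 4.5-fold lower number (0.65 log units; beyond the scatter) from compound 1 to compound 2 and a 12-fold lower number (1.08 log units; beyond the scatter) from compound 3 to compound 4, 2.7-fold (0.43 log units) apart, beyond the scatter of two such steps The exchange of dimethylamino for acetamido gives a 1.3-fold lower number from compound 2 to compound 4 (0.12 log units; within the scatter), so compound 2 and compound 4 cannot be ordered, yet this step does not simply repeat the earlier one between the pyridin-3-yl compounds: the same change on two cores in this assay, a 2.0-fold higher number (0.30 log units; within the scatter) from compound 1 to compound 3 and a 1.3-fold lower number (0.12 log units; within the scatter) from compound 2 to compound 4, 2.7-fold (0.43 log units) apart, beyond the scatter of two such steps The set therefore supports the direction of the pyridinyl change on these two cores only, does not support transferring its size from one core to another, and offers no explanation for the difference, with just one pair of compounds behind each step.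

The compounds shown leave open whether a third group in place of dimethylamino or acetamido, such as a primary amine, a carboxylic acid or a longer amide chain, would bring a step of the same direction and of either size. Also open, going by these compounds, is how pyridin-4-yl or an unsubstituted phenyl ring in place of the pyridinyl groups would compare on either core.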